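Swapping a chloro for isopropyl on an indole-type core

A few compounds are considered here, and "the series" means these few. Any claim that something is new, unique, unknown or untested is made for them only; others in the source may bear on it.

Of the compounds shown here, two have been measured in an assay on HEK293 cells for binding affinity to 5-hydroxytryptamine receptor 7 (Homo sapiens), read by radioligand binding; a higher number here means a weaker inhibitor, a lower number a stronger inhibitor. Compound 1 `Brc1ccc2ccn(CCN3CCN4CCCCC4C3)c2c1` gives 70 nM. Compound 2 `CN1CCCN(CCn2ccc3ccc(Cl)cc32)CC1` gives 34 nM, the lower of the two numbers, and the gap to compound 1 lies beyond the usual scatter of this assay. The next compound, compound 3 `CC(C)c1ccc2ccn(CCN3CCCN(C)CC3)c2c1`, is built from compound 2 by a single change: isopropyl in place of chloro on an aromatic carbon. Going by the values given here, no measured pair shows this kind of exchange, so its effect has to be guessed. The expectation is a moderate weakening, a step of a 2.4-fold higher number from compound 2 to compound 3 (0.37 log units; beyond the scatter) in this assay, since replacing a small halogen with a larger branched alkyl group on an aromatic ring often costs some affinity, though it may also be tolerated. Compound 3 is therefore expected to give 80 nM in this assay, within a range from 25 nM to 250 nM.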

Compound 3, inhibition constant: 145 nM
Beside the measured number, compound 3's estimate is 1.8-fold (0.26 log units) below it; the range from low to high includes it.
By their numbers in this assay, from the lowest: compound 2; then compound 1; then compound 3.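

In this assay, putting isopropyl in place of chloro on this aromatic carbon gives a 4.3-fold higher number from compound 2 to compound 3 (0.63 log units; beyond the scatter), so affinity here does respond to which group the position carries. The exchange adds carbon atoms in place of a single chlorine, and neither group brings a hydrogen-bond donor, a hydrogen-bond acceptor or a net charge, so even a change between two such plain substituents is enough to shift the number. No measurement shown here says why the number rises.

A single pair cannot show whether other groups on this carbon would follow the same trend as isopropyl or behave differently. Methyl, methoxy or nitrile at the same place, on the same side chain, would show how far the number moves with the group attached.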